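Trimming the side chain of compound 1: an expectation

The source may hold more compounds than are shown below. What is called first, only, known or untested is meant among the compounds shown, and "the series" means these compounds.

Compound 1 `COc1cc(N(C)CCN(C)C)c(NC(=O)c2ccncc2OC)cc1Nc1nccc(-c2cn(C)c3ccccc23)n1` was tested in a functional assay on A549 cells (Homo sapiens) for antiproliferative activity, read by MTT assay, with a stated time of 72 h (on this read-out lower numbers stand for stronger inhibition and higher numbers for weaker inhibition), where compound 1 gives 2690 nM. This is the lowest of the two numbers measured here. Its companion, compound 2 `COc1cc(N(C)CCN(C)C)c(NC(=O)c2cnccn2)cc1Nc1nccc(-c2cn(C)c3ccccc23)n1`, gives 4330 nM in the same assay, and the step of a 1.6-fold higher number from compound 1 to compound 2 (0.21 log units; within the scatter) concerns a change on the carbonyl carbon of the amide, not the part of the molecule altered next.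

Compound 3 `COc1cc(N(C)C)c(NC(=O)c2ccncc2OC)cc1Nc1nccc(-c2cn(C)c3ccccc23)n1` is not yet measured. It differs from compound 1 by hydrogen in place of (dimethylamino)methyl on a saturated chain carbon bound to a nitrogen on an aromatic ring; cut one bond further out, the change reads as 2-(dimethylamino)ethyl to methyl. Among the measured compounds shown here, no measured step touches this position, so the only known step gives no direct guide. With nothing to lean on, the expectation for compound 3 is a step of a 1.7-fold higher number from compound 1 to compound 3 (0.22 log units; within the scatter), toward a weaker number but not far from compound 1. Compound 3 is therefore estimated at 4500 nM, in a range from 1500 nM to 15000 nM.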

Compound 3, half-maximal inhibitory concentration: 3030 nM
For compound 3 the middle estimate is 1.5-fold (0.17 log units) above the measured one, within the range that was stated.
By their numbers in this assay, from the lowest: compounds 1, 3 and 2 (each within the scatter of the next).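

Among the compounds shown here, this is the first measured change at the saturated chain carbon bound to a nitrogen on an aromatic ring, and in this assay the step is a 1.1-fold higher number from compound 1 to compound 3 (0.05 log units; within the scatter) for the exchange of (dimethylamino)methyl for hydrogen. Read another way, the full 2-(dimethylamino)ethyl group can be cut to methyl in this pair without a difference that stands out from the scatter, so the terminal dimethylamino group of compound 1 is not required to reach this level of antiproliferative activity. Nothing available explains this result.

On these data alone, whether the same holds with the pyrazin-2-yl amide of compound 2 remains open. So does the effect of a longer chain ending in an amine, or of a carboxylic acid, on this nitrogen.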